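Bromo in place of chloro on the shared core

The source may report more compounds than this note shows. Statements on the series, on what has been measured and on what is new or still open speak of the compounds shown alone.

compound 1 `Cc1cccc(NC(=O)NC2CC(C)(C)Oc3ccc(Br)cc32)c1`: > 10000 nM
compound 2 `Cc1ccc(NC(=O)NC2CC(C)(C)Oc3ccc(Cl)cc32)cc1`: > 30000 nM

In a functional assay (aorta) with Rattus norvegicus as the target (on this read-out lower numbers stand for an effect already at smaller amounts and higher numbers for an effect only at larger amounts of compound), compound 1 gives only a limit, > 10000 nM. Compound 2 also gives only a limit, > 30000 nM, so compound 2 stands at the limit of > 30000 nM in this assay, at which 1 of the 2 values shown sits, rather than at a measured number. Compound 3 `Cc1ccc(NC(=O)NC2CC(C)(C)Oc3ccc(Br)cc32)cc1` differs from compound 2 by bromo in place of chloro on an aromatic carbon. Within the data shown here, no measured pair isolates this change. With compound 2 showing no effect within the tested range, the expected step of a number no higher from compound 2 to compound 3 (the limit leaves the size open) is none beyond the scatter. Compound 3 is therefore estimated at 30000 nM, between 10000 nM and 100000 nM, and is expected to return only a limit again.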

Compound 3, half-maximal effective concentration: > 30000 nM
Compound 3 was reported as a limit; the forecaster's own chance of this, stated with the estimate: 85%; the middle value sits exactly at the limit.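

Among these compounds, compound 3 gives only a limit, as do compound 1 and compound 2, so no step to compound 3 can be read. The compounds shown leave open whether bromo in place of chloro, or 4-methylphenyl in place of 3-methylphenyl, changes the effect at all.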